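Stretching a Methyl to a Butyl on Compound 1

This account rests on a few compounds, and the source may have more. Where it says the series, first, only, none or still open, it means among the compounds named here.

Compound 1 `Cc1ccc(-n2sc3ncccc3c2=O)cc1` gives 6200 nM
Compound 2 `O=c1ccsn1-c1ccc(Cl)c([N+](=O)[O-])c1` gives 23200 nM
Compound 3 `Cc1cc(C)c2c(=O)n(CC(=O)Nc3ccc(F)cc3C)sc2n1` gives 25700 nM

All of these values come from a functional assay on SK-N-SH cells (Homo sapiens) for inhibition (on this read-out higher numbers stand for weaker inhibition of growth and lower numbers for stronger inhibition of growth), and each one is the concentration needed to cut cell growth by half. Compound 1 has the lowest number of the three, so it is the strongest inhibitor of growth in this small set. Its gaps to compound 2 and to compound 3 both lie beyond the scatter of repeated measurements. Those two sit close to each other, within that scatter.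

The next compound to be tested is compound 4 `CCCCc1ccc(-n2sc3ncccc3c2=O)cc1`, which keeps the core of compound 1 and differs in a single place (propyl in place of hydrogen on a saturated chain carbon bound to an aromatic carbon). Put simply, the methyl of compound 1 becomes a butyl.

For the measured compounds named here, no two measured compounds differ in only one place, so there is no direct precedent for this change. The best starting point is therefore compound 1 itself, at 6200 nM in the same test, and only a small move with a wide margin seems reasonable. The estimated size of the change is a 1.2-fold lower number from compound 1 to compound 4 (0.09 log units; within the scatter) and it may well stay within the scatter. For compound 4 the expected value is 5000 nM (estimated range 1800 nM to 15000 nM).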

Compound 4, concentration for 50% growth inhibition: 8930 nM
Beside the measured number, compound 4's estimate is 1.8-fold (0.25 log units) below it; the measured number falls inside the stated range.
By their numbers in this assay, from the lowest: compounds 1 and 4 (each within the scatter of the next); then compounds 2 and 3 (each within the scatter of the next).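

For the compounds shown here, this is the first pair in the set that differs in one place only, which gives a direct reading of a saturated chain carbon bound to an aromatic carbon: in this assay, stretching methyl to butyl gives a 1.4-fold higher number from compound 1 to compound 4 (0.16 log units; within the scatter). That step lies within the scatter of repeated measurements, so compound 1 and compound 4 cannot be told apart in this test, and the core of compound 1 tolerates the butyl chain at this place with no readable loss of growth inhibition. Nothing measured here speaks to what lies behind this result.

Among the compounds shown, only methyl and butyl stand at this place, so it remains open whether a group of another kind, such as an amine, a carboxylic acid or a benzyl group, would move the number beyond the scatter. On these data alone, it is also open whether a longer chain, such as octyl, would stay within the scatter of compound 1 or would finally separate from it in either direction.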